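Aryl Swap on a Triazole Series at the Assay Limit

This account rests on a few compounds, and the source may have more. Where it says the series, first, only, none or still open, it means among the compounds named here.

Compound 1 `Cc1ccccc1-n1nncc1CN1C(=O)C2(C(C#N)=C(N)Oc3c2c2nc4ccccc4nc2c2ccccc32)c2ccccc21` sits at the assay limit in an ADME assay on HUVEC cells (Homo sapiens) for antiproliferative activity, read by MTT assay, with a stated time of 48 h (a higher number here means a weaker inhibitor, a lower number a stronger inhibitor), giving > 50000 nM.
Compound 2 `CCOc1ccccc1-n1nncc1CN1C(=O)C2(C(C#N)=C(N)Oc3c2c2nc4ccccc4nc2c2ccccc32)c2ccccc21` also sits at the assay limit, giving > 50000 nM.

Compound 2 therefore stands only at a limit in this assay, not at a measured number. Within the data shown here, the single measured step, a step that the two limits leave unreadable from compound 1 to compound 2, cannot be read because both of its ends rest on (the limit of > 50000 nM in this assay, at which 2 of the 2 values shown sit). The next compound, compound 3 `Cc1ccc(Cl)cc1-n1nncc1CN1C(=O)C2(C(C#N)=C(N)Oc3c2c2nc4ccccc4nc2c2ccccc32)c2ccccc21`, differs from compound 2 by the change (5-chloro-2-methylphenyl in place of 2-ethoxyphenyl on an aromatic nitrogen). No readable step among the measured compounds bears on this change, so nothing in the data points to a gain in inhibition. Compound 3 is expected to remain at or near the limit, with the step that the limit leaves unreadable from compound 2 to compound 3 expected to be unreadable. The estimate for compound 3 in this assay is 70000 nM, in a range from 20000 nM to 300000 nM.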

Compound 3, half-maximal inhibitory concentration: > 50000 nM
Compound 3: only a limit was reported; the forecaster's own chance of this, stated with the estimate: 85%; the middle value does not contradict the limit.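

Compound 3 adds no readable step from compound 1 or compound 2, because all three compounds rest on one limit: the limit of > 50000 nM in this assay, at which 3 of the 3 values shown sit.

Still open, from the compounds shown here alone, is how far these three compounds differ in this assay, and whether any other aryl group on the aromatic nitrogen would give a true number.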